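This account rests on a few compounds, and the source may have more. Where it says the series, first, only, none or still open, it means among the compounds named here.

Three compounds have so far been measured in a functional assay on MKN-45 cells (Homo sapiens) for cytotoxicity, read by MTT assay, with a stated time of 72 h; a higher number here means a weaker inhibitor, a lower number a stronger inhibitor:

compound 1, `COc1cc2c(Oc3ccc(NC(=O)c4nnn(-c5ccc(C)cc5)c4C(F)(F)F)cc3F)ccnc2cc1OCCCN1CCCC1`, gives 210 nM
compound 2, `COc1cc2c(Oc3ccc(NC(=O)c4nnn(-c5ccccc5C(F)(F)F)c4C)cc3F)ccnc2cc1OCCCN1CCCCC1`, gives 90 nM
compound 3, `COc1cc2c(Oc3ccc(NC(=O)c4nnn(-c5ccc(F)c(F)c5)c4C(F)(F)F)cc3F)ccnc2cc1OCCCN1CCCCC1`, gives 90 nM

All three share one large core and differ only in the aryl group on the triazole and in the saturated amine ring at the end of the side chain. On these numbers compound 3 sits level with compound 2 at the digits shown, the two being within the usual scatter of each other, so no order between them can be read. Compound 1 is the one that stands apart: its number is higher than that of compound 3 by a margin beyond the scatter, so it is the weaker inhibitor of the three.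

Compound 4, `COc1cc2c(Oc3ccc(NC(=O)c4nnn(-c5ccc(F)c(F)c5)c4C(F)(F)F)cc3F)ccnc2cc1OCCCN1CCC(C)CC1`, has not yet been measured. It differs from compound 3 in one place: methyl in place of hydrogen on a saturated ring carbon. Going by the values given here, no pair of measured compounds shows this particular change, so its effect has to be guessed. A single methyl added to the amine ring far from the amide is a small alteration, and the expectation is for a step of about no change at the digits printed from compound 3 to compound 4 (within the scatter) in this assay, no larger than the scatter itself in either direction. Compound 4 is therefore estimated to give 90 nM in this assay, with a plausible range from 40 nM to 200 nM.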

Compound 4, half-maximal inhibitory concentration: 50 nM
For compound 4 the middle estimate is 1.8-fold (0.26 log units) above the measured one, within the range that was stated.
By their numbers in this assay, from the lowest: compounds 4, 2 and 3 (each within the scatter of the next); then compound 1.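

In this assay, going by these compounds alone, placing a methyl on the saturated ring carbon three ring bonds from the ring nitrogen, which turns piperidin-1-yl into 4-methylpiperidin-1-yl, gives a 1.8-fold lower number from compound 3 to compound 4 (0.26 log units; within the scatter) as the first step between measured compounds that differ in one place. The earlier compounds shown here could not isolate any single change, whereas this pair shows that this ring carbon can carry a methyl without a loss of activity that can be read, and the two compounds cannot be put in order. No measurement is available that bears on what lies behind this result.

Going by these compounds, whether this carbon would also accept something larger or different, such as an ethyl group, a phenyl ring, a hydroxyl group or a carboxylic acid, remains open. Also open, on these data alone, is whether a methyl on another carbon of the ring, or the same methyl combined with the aryl group of compound 2 on the triazole, would leave the number just as close.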